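The source may report more compounds than this note shows. Statements on the series, on what has been measured and on what is new or still open speak of the compounds shown alone.

Measured compounds:
Compound 1, `Cc1ccc(NC(=O)Nc2nc(Nc3ccccc3)cc(Sc3c[nH]c4ccccc34)n2)cc1`, gives 14900 nM in a functional assay on HepG2 cells (Homo sapiens) for inhibition, with a stated time of 72 h; a lower number here means a stronger inhibitor, a higher number a weaker inhibitor.
Compound 2, `COc1ccc(NC(=O)Nc2nc(Sc3c[nH]c4ccccc34)cc(N3CCCCC3)n2)cc1`, gives 17100 nM in this assay.
Compound 3, `COc1ccc(NC(=O)Nc2nc(Nc3cc(OC)cc(OC)c3)cc(Sc3c[nH]c4ccccc34)n2)cc1`, gives 17400 nM in this assay.

All three compounds share the same core and differ only in the groups attached to it. Compound 1 stands within the usual scatter of both compound 2 and compound 3, so the three numbers cannot be told apart. The only measured step between two compounds that differ in one place is a 1.0-fold higher number from compound 2 to compound 3 (0.01 log units; within the scatter); it concerns a different part of the shared core than the change now considered, and offers only an indirect hint that this series has so far shown no shift beyond the scatter.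

Compound 4, `O=C(Nc1ccccc1)Nc1nc(Nc2ccccc2)cc(Sc2c[nH]c3ccccc23)n1`, differs from compound 1 by hydrogen in place of methyl on an aromatic carbon. Going by the values given here, no measured pair shows this particular change, so the expectation rests on the flat picture across compound 1, compound 2 and compound 3: a single heavy atom leaves, with no ring and no donor or acceptor involved. The expected step is therefore a 1.1-fold higher number from compound 1 to compound 4 (0.03 log units; within the scatter), within the scatter, with no preferred direction. Compound 4 is estimated at 16000 nM, with a range from 7000 nM to 36000 nM.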

Compound 4, half-maximal inhibitory concentration: 14400 nM
For compound 4 the middle estimate is 1.1-fold (0.05 log units) above the measured one; the measured number falls inside the stated range.
By their numbers in this assay, from the lowest: compounds 4, 1, 2 and 3 (each within the scatter of the next).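

In this assay, going by these compounds alone, the only measured step at this position is a 1.0-fold lower number from compound 1 to compound 4 (0.01 log units; within the scatter), for hydrogen in place of methyl on an aromatic carbon. The earlier compounds shown here offered only an indirect hint about this place, whereas this pair tests it directly: on a six-membered aromatic ring of carbon only, para to a large group, 4-methylphenyl and phenyl cannot be told apart by their numbers, so the methyl can go without a shift beyond the scatter. Nothing among the data given accounts for this flat result.

This single pair covers only methyl and hydrogen, so it leaves open whether a group of a different kind at the same place, such as a carboxylic acid, an amine or a longer chain, would move the number beyond the scatter. Compound 2 and compound 3 carry a methoxy group on the corresponding ring, but each also differs from compound 1 elsewhere, so the effect of methoxy at this place stays unresolved.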